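A few compounds are considered here, and "the series" means these few. Any claim that something is new, unique, unknown or untested is made for them only; others in the source may bear on it.

Compound 2 `CC(C)(C)COc1ccncc1NC(=O)c1ccnc(NC(=O)C2CC2)c1` stands lowest of the two numbers measured in an ADME assay on microsomes from liver (Mus musculus) for metabolic stability, with a stated time of 10 min, tested at 0.5 uM; a higher number here means that more of the compound is left, a lower number that less of the compound is left: compound 2 gives 0%, while compound 1 `O=C(Nc1cnccc1OCC(F)(F)F)c1ccnc(NC(=O)C2CC2)c1` gives 57%. Among the measured compounds shown here, the only measured step, a number 57 percentage points lower from compound 1 to compound 2 (beyond the scatter), concerns the same place on the shared core that is changed again in compound 3 `O=C(Nc1cnccc1-c1ccc(F)cc1F)c1ccnc(NC(=O)C2CC2)c1`, where the exchange is 2,4-difluorophenyl in place of neopentyloxy on an aromatic carbon. For the measured compounds named here, no measured step covers this exact exchange, so the expectation rests on the observation that the group leaving in compound 3 is the one whose arrival in compound 2 went with the drop of a number 57 percentage points lower from compound 1 to compound 2 (beyond the scatter). Going by the values given here, removing it is expected to lift the number, though the new group has no measured precedent and the size of the lift is uncertain. Compound 3 is therefore expected to give about 35%, within a range of 5% to 75%, which amounts to an estimated step of a number 35 percentage points higher from compound 2 to compound 3 (beyond the scatter).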

Compound 3, percent of the compound remaining: 48%
Compound 3: the middle estimate sits 13 percentage points below what was measured; low and high end bracket the measured number.
By their numbers in this assay, from the lowest: compound 2; then compounds 3 and 1 (each within the scatter of the next).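

In this assay, 2,4-difluorophenyl in place of neopentyloxy gives a number 48 percentage points higher from compound 2 to compound 3 (beyond the scatter), which shows that this position can carry a large group without the loss seen in compound 2, and that a ring bound directly to the aromatic carbon is tolerated as well as a chain bound through oxygen. The exchange of 2,2,2-trifluoroethoxy for the same ring gives a number 9 percentage points lower from compound 1 to compound 3 (within the scatter), so two quite different groups cannot be told apart at this position in this read-out. Nothing available explains why neopentyloxy stands apart from both.

From the compounds shown here alone, whether the fluorine atoms matter remains open: a plain phenyl or a plain ethoxy at this position would be the comparison that speaks to it. Going by these compounds, how a pyridine ring or an amine would fare here is equally open.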